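This account rests on a few compounds, and the source may have more. Where it says the series, first, only, none or still open, it means among the compounds named here.

Measured so far in a functional assay on MGC-803 cells (Homo sapiens) for inhibition, read by sulforhodamine B assay; a higher number here means a weaker inhibitor, a lower number a stronger inhibitor:
Compound 1 `CCCc1ccc(NC2=CC(=O)c3nc4n(c3C2=O)[C@H]2OC[C@@H](O)[C@H]2OC4)cc1` gives 1560 nM
Compound 2 `Cc1ccc(NC2=CC(=O)c3c(nc4n3[C@H]3OC[C@@H](O)[C@H]3OC4)C2=O)cc1C` gives 1050 nM
Compound 3 `COc1ccccc1NC1=CC(=O)c2c(nc3n2[C@H]2OC[C@@H](O)[C@H]2OC3)C1=O` gives 1670 nM

These three numbers lie within the usual scatter of one another, so compound 1 stands level with compound 2 and compound 3, and no order can be drawn among them. Compound 4 `O=C1C=C(Nc2cccc(F)c2)C(=O)c2c1nc1n2[C@H]2OC[C@@H](O)[C@H]2OC1` is still to be measured in this assay and keeps the core of compound 1. Going by the values given here, its one change is 3-fluorophenyl in place of 4-propylphenyl on an amine nitrogen and the rest of the structure stays the same.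

Among the compounds with values here, one measured step bears on this change. Placing 2-methoxyphenyl in place of 3,4-dimethylphenyl on an amine nitrogen gave a 1.6-fold higher number from compound 2 to compound 3 (0.20 log units; within the scatter) and so moved the number by no more than the scatter. Within the data shown here, this is thin evidence, since it is a single step and no measured compound carries 3-fluorophenyl. On this evidence, no change beyond the scatter is expected here. The expected step is a 1.0-fold lower number from compound 1 to compound 4 (0.02 log units; within the scatter) and would stay within the scatter. Compound 4 is estimated at 1500 nM with 750 nM and 3000 nM as the expected ends of its range.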

Compound 4, half-maximal inhibitory concentration: 2180 nM
Compound 4: the middle estimate sits 1.5-fold (0.16 log units) below what was measured; low and high end bracket the measured number.
By their numbers in this assay, from the lowest: compounds 2, 1, 3 and 4 (each within the scatter of the next, the first and the last beyond it).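

In this assay, 3-fluorophenyl in place of 4-propylphenyl on an amine nitrogen gave a 1.4-fold higher number from compound 1 to compound 4 (0.15 log units; within the scatter), a step that stays within the scatter, so losing the propyl chain and gaining a fluorine on the phenyl ring left the number level with that of compound 1. Going by these compounds alone, the result does widen the set in one respect: compound 2 at 1050 nM and compound 4 at 2180 nM are the first pair to stand beyond the scatter of each other, although each compound remains within the scatter of its neighbour in the order. No measurement among these data bears on why this position tolerates such a change, and the result therefore stands without an explanation.

From the compounds shown here alone, all four compounds carry a substituted phenyl on this nitrogen, so it remains open whether a cyclohexyl group, a plain alkyl chain or a phenyl bearing a carboxylic acid or an amine would move the number beyond the scatter. Going by these compounds, it also remains open whether 4-fluorophenyl or 2-fluorophenyl would read differently from 3-fluorophenyl.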